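The source may hold more compounds than are shown below. What is called first, only, known or untested is meant among the compounds shown, and "the series" means these compounds.

Measured compounds in a functional assay on LNCaP cells (Homo sapiens) for cytotoxicity; on this read-out higher numbers stand for weaker inhibition and lower numbers for stronger inhibition: compound 1 `O=C(Nc1ccc(-c2nc(N3CC4CCC(C3)O4)c3sccc3n2)cc1)Nc1cccnc1`, 27 nM; compound 2 `COC(=O)Nc1ccc(-c2nc(N3CC4CCC(C3)O4)c3sccc3n2)cc1`, 1850 nM; compound 3 `O=C(Nc1ccc(-c2nc(N3CC4CCC(C3)O4)c3sccc3n2)cc1)NC1CC1`, 40 nM.

Compound 3 holds the second highest of the three numbers: its step to compound 1, a 1.5-fold higher number from compound 1 to compound 3 (0.17 log units; within the scatter), lies within the scatter, while compound 2 is far off, a 46-fold lower number from compound 2 to compound 3 (1.67 log units; beyond the scatter). Compound 4 `CC(=O)Nc1ccc(-c2nc(N3CC4CCC(C3)O4)c3sccc3n2)cc1` differs from compound 3 by methyl in place of cyclopropylamino on a carbonyl carbon. For the measured compounds named here, two measured steps bear on this: the move from compound 1 to compound 2, a 69-fold higher number from compound 1 to compound 2 (1.84 log units; beyond the scatter), and the reverse-direction move from compound 2 to compound 3, a 46-fold lower number from compound 2 to compound 3 (1.67 log units; beyond the scatter), both large and both exchanging an amino group on the carbonyl carbon for a group without one. Compound 4 likewise loses the amino group, so a large rise in the number is expected; the expected step is a 38-fold higher number from compound 3 to compound 4 (1.57 log units; beyond the scatter). For compound 4 the estimate is 1500 nM, in the range 400 nM to 6000 nM.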

Compound 4, half-maximal inhibitory concentration: 1700 nM
For compound 4 the middle estimate is 1.1-fold (0.05 log units) below the measured one; the range from low to high includes it.
By their numbers in this assay, from the lowest: compounds 1 and 3 (each within the scatter of the next); then compounds 4 and 2 (each within the scatter of the next).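

In this assay, a carbonyl carbon carrying methyl behaves like one carrying methoxy (a 1.1-fold lower number from compound 2 to compound 4 (0.04 log units; within the scatter)), so the high number is not specific to the carbamate oxygen. Both amino-bearing compounds sit far from methyl, with cyclopropylamino (a 43-fold higher number from compound 3 to compound 4 (1.63 log units; beyond the scatter)) and (pyridin-3-yl)amino (a 63-fold higher number from compound 1 to compound 4 (1.80 log units; beyond the scatter)) giving large steps of similar size, and none of the four compounds goes against this split. No measurement shown offers an explanation for the split. Open, going by these compounds, is whether dimethylamino on this carbonyl carbon, which keeps the nitrogen but lacks its hydrogen, stays with the low-number compounds or joins the high-number ones.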